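Swapping a branched alkyl for a naphthalene on the shared core

The compounds below may be only part of what the source reports. "The series", "measured", "known", "first", "only" and "open" are said of these compounds alone.

Measured compounds:
- compound 1 `Fc1ccc(Oc2ccc3c(NCCCNCc4ccco4)ccnc3c2)cc1`: 14500 nM
- compound 2 `CCC(CC)c1ccc2c(NCCCNCc3cccc(OC)c3O)ccnc2c1`: 4200 nM
- compound 3 `COc1ccc(-c2ccc3c(NCCCNCc4ccco4)ccnc3c2)cc1`: 32000 nM

These three compounds were measured in a physicochemical assay for solubility, with a stated time of 18 h, at pH 7.4; a lower number here means a less soluble compound, a higher number a more soluble compound. Compound 2 stands lowest of the three numbers; compound 1 sits nearer to it and compound 3 furthest from it. For the measured compounds named here, the only single-point step among them is a 2.2-fold higher number from compound 1 to compound 3 (0.34 log units; beyond the scatter).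

Compound 4 `COc1cccc(CNCCCNc2ccnc3cc(-c4cccc5ccccc45)ccc23)c1O` has not yet been measured. It differs from compound 2 by naphthalen-1-yl in place of pentan-3-yl on an aromatic carbon. Going by the values given here, no measured step involves pentan-3-yl or naphthalen-1-yl, so none bears directly on this change. Compound 3, which carries an aromatic ring at a corresponding position, gives the highest number, but it also differs from compound 2 in the side chain, so its value cannot be read as a guide for this step alone. Without a direct precedent, the expectation for compound 4 is a step of a 1.7-fold lower number from compound 2 to compound 4 (0.23 log units; within the scatter), within or slightly beyond the scatter and more likely downward than upward. The estimate for compound 4 in this assay is therefore 2500 nM, with a range from 600 nM to 10000 nM.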

Compound 4, solubility: 32000 nM
The estimate for compound 4 lay 13-fold (1.11 log units) below the measured number; measured number outside the range, above it.
By their numbers in this assay, from the lowest: compound 2; then compound 1; then compounds 3 and 4 (each within the scatter of the next).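

In this assay, for the compounds shown here, the step of a 7.6-fold higher number from compound 2 to compound 4 (0.88 log units; beyond the scatter) gives the first direct reading of this change on the shared core, and it goes upward. The entering naphthalen-1-yl has 10 heavy atoms and two aromatic rings, against 5 heavy atoms and no ring in the leaving pentan-3-yl, so in this pair the larger all-carbon group comes with the higher number. No measurement shown here offers a reason for this rise.

One pair cannot separate the effect of the two aromatic rings from that of the overall size of the group. A cyclohexyl group or a simple phenyl at this position of compound 2 would help to tell these apart, and a morpholine would show how a ring carrying nitrogen and oxygen compares.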